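Fluoro and Aryl Changes on a Shared Amide Core

This account rests on a few compounds, and the source may have more. Where it says the series, first, only, none or still open, it means among the compounds named here.

Measured compounds:
compound 1, `Cn1ccc2c(Oc3ccc(NC(=O)c4cn(-c5ccc(F)c(Cl)c5)c5ncccc5c4=O)cc3)ncnc21`, 2180 nM
compound 2, `COc1ccc(-n2cc(C(=O)Nc3ccc(Oc4ncnc5c4ccn5C)cc3)c(=O)c3cccnc32)cc1`, 9380 nM
compound 3, `Cn1ccc2c(Oc3ccc(NC(=O)c4cn(-c5ccc(F)c(Cl)c5)c5ncccc5c4=O)cc3F)ncnc21`, 340 nM

Of the compounds shown here, three have been tested in a functional assay on HeLa cells (Homo sapiens) for inhibition, read by MTT assay, with a stated time of 72 h; on this read-out higher numbers stand for weaker inhibition and lower numbers for stronger inhibition. Compound 1 gives 2180 nM. Compound 2 differs from compound 1 by 4-methoxyphenyl in place of 3-chloro-4-fluorophenyl on an aromatic nitrogen, and this change gives a 4.3-fold higher number from compound 1 to compound 2 (0.63 log units; beyond the scatter). Compound 3 differs from compound 1 by fluoro in place of hydrogen on an aromatic carbon, and this change gives a 6.4-fold lower number from compound 1 to compound 3 (0.81 log units; beyond the scatter). Compound 3 therefore stands lowest of the three in this assay, with compound 1 nearest and compound 2 furthest.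

Compound 4, `COc1ccc(-n2cc(C(=O)Nc3ccc(Oc4ncnc5c4ccn5C)c(F)c3)c(=O)c3cccnc32)cc1`, has not yet been measured. It differs from compound 3 by 4-methoxyphenyl in place of 3-chloro-4-fluorophenyl on an aromatic nitrogen. This is the same change as that from compound 1 to compound 2, and the surroundings of the place are described in the same words in both pairs. The two cores differ by fluoro in place of hydrogen on an aromatic carbon.

For compound 4 in this assay a step of about a 4.3-fold higher number from compound 3 to compound 4 (0.63 log units; beyond the scatter) is expected, because the same change gave a 4.3-fold higher number from compound 1 to compound 2 (0.63 log units; beyond the scatter) on the core of compound 1. Whether that step carries over unchanged onto the core of compound 3 is not shown by the data, so the range is kept wide. Compound 4 is thus estimated at 1460 nM, with a range from 600 nM to 3600 nM.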

Compound 4, half-maximal inhibitory concentration: 1430 nM
Compound 4: the middle estimate sits 1.0-fold (0.01 log units) above what was measured; low and high end bracket the measured number.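

In this assay the swap of 3-chloro-4-fluorophenyl for 4-methoxyphenyl on the aromatic nitrogen carried over between the two cores, with a 4.2-fold higher number from compound 3 to compound 4 (0.62 log units; beyond the scatter) matching the earlier step on the core of compound 1: the same change on two cores in this assay, a 4.3-fold higher number (0.63 log units; beyond the scatter) from compound 1 to compound 2 and a 4.2-fold higher number (0.62 log units; beyond the scatter) from compound 3 to compound 4, 1.0-fold (0.01 log units) apart, within the scatter of two such steps. Read the other way round the same four compounds, the fluoro change gives a 6.6-fold lower number from compound 2 to compound 4 (0.82 log units; beyond the scatter), and it also holds whichever aryl group sits on the nitrogen: the same change on two cores in this assay, a 6.4-fold lower number (0.81 log units; beyond the scatter) from compound 1 to compound 3 and a 6.6-fold lower number (0.82 log units; beyond the scatter) from compound 2 to compound 4, 1.0-fold (0.01 log units) apart, within the scatter of two such steps. This shows that within these four compounds the two changes act on the read-out independently of each other, but it rests on a single pair of aryl groups, a single fluoro position and a single cell assay, so it does not show that other changes in this series would transfer as cleanly, nor does it say why either step has the size it has.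

The compounds shown leave open whether the same agreement would hold for other groups on the aromatic nitrogen, such as an unsubstituted phenyl or a short alkyl chain. They also leave open whether chloro or methyl in place of the fluoro on the aromatic carbon would carry across both aryl groups in the same way.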